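Oxadiazole to chlorophenoxy swap in the pyrazole amide series

The compounds below may be only part of what the source reports. "The series", "measured", "known", "first", "only" and "open" are said of these compounds alone.

Compound 1 `Cn1ncc(Cl)c1C(=O)NCc1ccc(-c2noc(C3CC3)n2)cc1` gives 24300 nM in a toxicity assay on MCF-10A cells (Homo sapiens) for cytotoxicity; on this read-out higher numbers stand for weaker inhibition and lower numbers for stronger inhibition. Its nearest neighbour is compound 3 `Cc1ccc(Oc2ccc(CNC(=O)c3c(F)cnn3C)cc2)cc1`, which gives 13700 nM, a gap within the scatter of repeated measurements. Compound 2 `CCc1nc(-c2ccc(CNC(=O)c3c(Cl)c(CC)nn3C)cc2)no1` gives > 50000 nM, which is a limit of the assay rather than a number. One value therefore sits at the limit of > 50000 nM in this assay, at which 1 of the 3 values shown sits. Among the two actual numbers, compound 1 holds the higher one.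

Compound 4 `Cn1ncc(Cl)c1C(=O)NCc1ccc(Oc2ccc(Cl)cc2)cc1` differs from compound 1 in one place: 4-chlorophenoxy in place of 5-cyclopropyl-1,2,4-oxadiazol-3-yl on an aromatic carbon. Going by the values given here, no measured pair shares this change, so it has no direct precedent in the set. The step is expected to stay within the scatter, a 1.2-fold lower number from compound 1 to compound 4 (0.08 log units; within the scatter), with no clear direction. For compound 4 the estimate in this assay is 20000 nM, ranging from 8000 nM to 50000 nM.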

Compound 4, half-maximal inhibitory concentration: > 50000 nM
Compound 4: no number, only a limit (the forecaster's own chance of this, stated with the estimate: 20%); at least 2.5-fold (0.39 log units) between middle value and limit.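

In this assay, going by these compounds alone, the change to 4-chlorophenoxy on this aromatic carbon gives the first one-place step, an at least 2.0-fold higher number from compound 1 to compound 4 (0.31 log units; beyond the scatter). The group at this position therefore moves the read-out beyond the scatter, towards weaker inhibition. The value of compound 4 is a limit, not a number, so the full size of the step stays unknown: the limit of > 50000 nM in this assay, at which 2 of the 4 values shown sit.

A single step cannot separate the chlorine from the ring or the ether oxygen of 4-chlorophenoxy. Going by these compounds, how an amine or a carboxylic acid on this aromatic carbon would read also remains open.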